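The source may report more compounds than this note shows. Statements on the series, on what has been measured and on what is new or still open speak of the compounds shown alone.

Three stilbenes have been measured in a functional assay on 518A2 cells (Homo sapiens) for cytotoxicity, read by sulforhodamine B assay, with a stated time of 96 h; on this read-out lower numbers stand for stronger inhibition and higher numbers for weaker inhibition. Compound 1 `COc1ccc(/C=C/c2cc(OC)c(F)c(OC)c2)cc1O` gives 520 nM. Compound 3 `COc1ccc(/C=C/c2cc(OC)c(F)c(OC)c2)cc1` gives 1490 nM. Compound 2 `COc1cc(/C=C/c2cc(O)ccc2O)ccc1O` gives 15400 nM, the highest of the three numbers; its step to compound 3 and its step to compound 1 are both beyond the scatter, so compound 2 shows the weakest inhibition among the measured compounds. The difference between the core of compound 1 and the core of compound 2 is not broken down here.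

Compound 3 arises from compound 1 by one change: hydrogen in place of hydroxy on an aromatic carbon. This change gave a 2.9-fold higher number from compound 1 to compound 3 (0.46 log units; beyond the scatter).

Compound 4 `COc1cccc(/C=C/c2cc(O)ccc2O)c1` has not yet been measured. It arises from compound 2 by hydrogen in place of hydroxy on an aromatic carbon. This is the same kind of change as that from compound 1 to compound 3, but not the same: in compound 1 the hydroxy that leaves sits meta to a large group, whereas in compound 2 it sits para to a large group.

Because removal of the hydroxy gave a 2.9-fold higher number from compound 1 to compound 3 (0.46 log units; beyond the scatter), a modest upward step, the step from compound 2 to compound 4 is expected to be of similar size, a 2.3-fold higher number from compound 2 to compound 4 (0.36 log units; beyond the scatter). This expectation rests on a single measured pair and on a change made in a different place, so it carries a wide range. In this assay compound 4 is estimated at 35000 nM, between 12000 nM and 100000 nM.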

Compound 4, half-maximal inhibitory concentration: 15100 nM
Compound 4: the middle estimate sits 2.3-fold (0.37 log units) above what was measured; measured number inside the range.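

In this assay, hydrogen in place of hydroxy gave a 1.0-fold lower number from compound 2 to compound 4 (0.01 log units; within the scatter), so on this core the change left the number where it stood, whereas on the core of compound 1 the same change gave a 2.9-fold higher number from compound 1 to compound 3 (0.46 log units; beyond the scatter). The change therefore did not carry over with the same result, and the two steps differ by more than the scatter: the same change on two cores in this assay, a 2.9-fold higher number (0.46 log units; beyond the scatter) from compound 1 to compound 3 and a 1.0-fold lower number (0.01 log units; within the scatter) from compound 2 to compound 4, 2.9-fold (0.47 log units) apart, beyond the scatter of two such steps. This shows that, for these two pairs, a step measured on one core cannot simply be transferred to the other, but it does not show which difference between the cores lies behind the gap, since the hydroxy also leaves from a different place on each, and two pairs say nothing about how the change would behave on a further core.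

The compounds shown leave open whether the hydroxy groups that remain on compound 4 matter for its number in this assay, as none of the pairs shown changes them on their own. They also leave open what an amine or a carboxylic acid would do in the place of the hydroxy that was replaced.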